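From (Hydroxymethyl)carbonyl to Cyclopropylsulfonyl on a Ring Amine

The compounds below may be only part of what the source reports. "The series", "measured", "known", "first", "only" and "open" are said of these compounds alone.

Measured compounds:
Compound 1, `CN1CCN(c2ccc(Nc3ncc4nc(Nc5ccccc5)n([C@H]5CCN(S(C)(=O)=O)C5)c4n3)cc2)CC1`, in a functional assay on A-431 cells (Homo sapiens) for antiproliferative activity, read by MTT assay, with a stated time of 72 h; on this read-out higher numbers stand for weaker inhibition and lower numbers for stronger inhibition: "not determined" (no result reported)
Compound 2, `CN1CCN(c2ccc(Nc3ncc4nc(Nc5ccc(F)cc5)n([C@H]5CCN(C(=O)CO)C5)c4n3)cc2)CC1`: "not determined" (no result reported)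
Compound 3, `CN1CCN(c2ccc(Nc3ncc4nc(Nc5ccccc5)n([C@@H]5CCN(S(=O)(=O)C6CC6)C5)c4n3)cc2)CC1`: > 10000 nM

All three share a common core and differ in the group carried on the amine nitrogen of the five-membered ring. Compound 2 has no single number in this assay; of the other two entries, one is a limit and one has no number. For compound 3 the result in this assay is only a limit, > 10000 nM, which is one value of the three shown (the limit of > 10000 nM in this assay, at which 1 of the 3 values shown sits).

Compound 4, `CN1CCN(c2ccc(Nc3ncc4nc(Nc5ccc(F)cc5)n([C@H]5CCN(S(=O)(=O)C6CC6)C5)c4n3)cc2)CC1`, is the compound still to be measured. It differs from compound 2 in one place: cyclopropylsulfonyl in place of (hydroxymethyl)carbonyl on an amine nitrogen in a ring. Among the compounds with values here, no measured pair shows this change, so no size or direction for the step from compound 2 to compound 4 can be taken from the data, and no shift beyond the usual scatter can be asserted.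

With that caveat, compound 4 is expected to give about 300 nM in this assay, within a broad range from 30 nM to 5000 nM.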

Compound 4, half-maximal inhibitory concentration: 1670 nM
Beside the measured number, compound 4's estimate is 5.6-fold (0.75 log units) below it, and the stated range covers the measured number.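

Within the data shown here, compound 2 has no single number in this assay, so no step to compound 4 can be read. What replacing (hydroxymethyl)carbonyl with cyclopropylsulfonyl does to antiproliferative activity stays open, and nothing shown here helps to explain the result for compound 4.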